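Fluoropiperidine in Place of Methylpiperidine: Rat Exposure

The compounds below may be only part of what the source reports. "The series", "measured", "known", "first", "only" and "open" are said of these compounds alone.

Of the compounds shown here, two have been measured in an ADME assay on the whole organism (plasma) for pharmacokinetics, with Rattus norvegicus as the target, with a stated time of 6 h, at a dose of 10 mg/kg by the oral route; on this read-out lower numbers stand for lower exposure and higher numbers for higher exposure at the dose given. Compound 1 `FC(F)(F)c1cccc(-c2c[nH]c(-c3cccc(CN4CCCCC4)c3)n2)c1` gives 207 ng.h/mL. Going by the values given here, compound 2 `CC1CCCN(Cc2cccc(-c3nc(-c4cccc(C(F)(F)F)c4)c[nH]3)c2)C1` gives 564 ng.h/mL, the higher of the two numbers; the single measured step, a 2.7-fold higher number from compound 1 to compound 2 (0.44 log units; beyond the scatter), separates them, so compound 2 stands at the top of what is known.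

Compound 3 `FC1CCN(Cc2cccc(-c3nc(-c4cccc(C(F)(F)F)c4)c[nH]3)c2)CC1` has not yet been measured. It differs from compound 2 by 4-fluoropiperidin-1-yl in place of 3-methylpiperidin-1-yl on a saturated chain carbon bound to an aromatic carbon. Among the compounds with values here, no measured pair shows this exact exchange. Within the data shown here, the only step that bears on it, a 2.7-fold higher number from compound 1 to compound 2 (0.44 log units; beyond the scatter), shows that adding the methyl on the saturated ring raised the number beyond the scatter. Among the measured compounds shown here, compound 3 gives up that methyl while taking on a fluorine, and no measured pair shows what the fluorine alone does.

The analyst therefore expects the number for compound 3 to drop back toward the level of compound 1, with wide uncertainty, estimated at 300 ng.h/mL within 120 ng.h/mL to 750 ng.h/mL. The expected step is a 1.9-fold lower number from compound 2 to compound 3 (0.27 log units; within the scatter).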

Compound 3, area under the concentration-time curve: 211 ng.h/mL
Compound 3: the middle estimate sits 1.4-fold (0.15 log units) above what was measured; measured number inside the range.
By their numbers in this assay, from the lowest: compounds 1 and 3 (each within the scatter of the next); then compound 2.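

In this assay, the change to 4-fluoropiperidin-1-yl on the saturated chain carbon bound to an aromatic carbon gives a 2.7-fold lower number from compound 2 to compound 3 (0.43 log units; beyond the scatter), a step of about the same size as a 2.7-fold higher number from compound 1 to compound 2 (0.44 log units; beyond the scatter) but in the opposite direction. The added fluorine, taken alone, gives a 1.0-fold higher number from compound 1 to compound 3 (0.01 log units; within the scatter), so this fluorine leaves compound 3 level with compound 1, and the higher number of compound 2 is not carried over to compound 3. Among these three compounds, only compound 2, with its 3-methylpiperidin-1-yl group, stands apart from the other two, and nothing in hand explains this result.

Going by these compounds, compound 2 and compound 3 differ in both the substituent and its place on the ring, so it stays open whether the higher number of compound 2 belongs to the methyl itself or to where it sits. On these data alone, it also stays open what a morpholine ring or a pyrrolidine ring would give on the same saturated chain carbon, with the rest of the structure unchanged.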